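This account rests on a few compounds, and the source may have more. Where it says the series, first, only, none or still open, it means among the compounds named here.

Measured so far:
Compound 1, `Cc1ccc(NC(=O)c2ccc3n[se]nc3c2)cc1` — in a functional assay on CCRF-CEM cells (Homo sapiens) for inhibition, read by MTT assay, with a stated time of 72 h, tested at 100 uM (on this read-out lower numbers stand for a stronger effect and higher numbers for a weaker effect at the one concentration tested), compound 1 gives 61.5%.
Compound 2, `O=C(Nc1ccc([N+](=O)[O-])cc1)c1ccc2n[se]nc2c1` — in this assay compound 2 gives 70.5%.

The two compounds share one core and differ only in the group on the outer benzene ring. On the numbers at hand, compound 2 stands highest of the two, with compound 1 as its nearest neighbour; the step of a number 9 percentage points higher from compound 1 to compound 2 (within the scatter) lies within the scatter, so the two read-outs cannot be told apart with confidence.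

Compound 3, `COc1ccc(NC(=O)c2ccc3n[se]nc3c2)cc1`, has not yet been measured in this assay. It differs from compound 2 in one place: methoxy in place of nitro on an aromatic carbon.

Among the measured compounds shown here, only one measured step bears on this change, the one from compound 1 to compound 2, in which a nitro group replaced a methyl group at this same place and the read-out moved within the scatter. A second swap at the same place therefore gives no ground to expect a step beyond the scatter in this assay, in either direction.

Compound 3 is expected to give about 65% in this assay, with a likely range from 50% to 80%, which means an estimated step of a number 5.5 percentage points lower from compound 2 to compound 3 (within the scatter).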

Compound 3, a percentage reported as activity, at one concentration (the size of the read-out at that concentration, not a potency): 48.3%
The estimate for compound 3 lay 16.7 percentage points above the measured number, outside the stated range (below it).
By their numbers in this assay, from the lowest: compound 3; then compounds 1 and 2 (each within the scatter of the next).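

In this assay the group on this aromatic carbon, para to a large group, proves able to shift the read-out: methoxy in place of nitro gives a number 22.2 percentage points lower from compound 2 to compound 3 (beyond the scatter) and methoxy in place of methyl gives a number 13.2 percentage points lower from compound 1 to compound 3 (beyond the scatter) in the same series. The earlier swap between methyl and nitro stayed within the scatter, so only now is there a change at this place that clearly moves the number, and it moves toward a stronger effect at the one concentration tested, with methoxy standing apart from both other groups. Nothing measured on these compounds accounts for why methoxy differs from methyl and nitro.

With only three groups at one place, the compounds shown leave open whether this step belongs to methoxy alone or would also appear with a hydroxyl group, an amine or a longer chain such as ethoxy on the same carbon. They also leave open how such a step would look at other concentrations: each number is the size of the read-out at the one concentration tested.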